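Dithioester Enaminones and Lymphocyte Proliferation: Expecting Compound 4

This account rests on a few compounds, and the source may have more. Where it says the series, first, only, none or still open, it means among the compounds named here.

Measured compounds:
compound 1, `CCCCCCCCCCCSC(=S)C1=C(Nc2ccc(Cl)cc2)CC(C)(C)CC1=O`, > 50 ug/mL
compound 2, `CC1(C)CC(=O)C(C(=S)SCc2ccccc2)=C(Nc2ccc(Cl)cc2)C1`, > 50 ug/mL
compound 3, `CCCCCCCCCCCSC(=S)C1=C(Nc2ccc(Br)cc2)CC(C)(C)CC1=O`, > 50 ug/mL

Three compounds sharing one core were tested in a functional assay on PBMC cells (Homo sapiens) for inhibition, read by thymidine incorporation, with a stated time of 72 h; a lower number here means a stronger inhibitor, a higher number a weaker inhibitor. Compound 1 gives > 50 ug/mL, and this value is a limit of the assay, not a number. Compound 2 gives > 50 ug/mL in this assay, again a limit rather than a number. Compound 3 gives > 50 ug/mL, also a limit. All three sit together, as the limit of > 50 ug/mL in this assay, at which 3 of the 3 values shown sit, states.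

Compound 2 differs from compound 1 by phenyl in place of decyl on a saturated chain carbon bound to a sulfur. The step that the two limits leave unreadable from compound 1 to compound 2 cannot be read because both values are limits. Compound 3 differs from compound 1 by bromo in place of chloro on an aromatic carbon, and the step that the two limits leave unreadable from compound 1 to compound 3 is likewise unreadable for the same reason.

Compound 4, `CC1(C)CC(=O)C(C(=S)SCc2ccccc2)=C(Nc2ccc(Br)cc2)C1`, has not yet been measured. It differs from compound 3 by phenyl in place of decyl on a saturated chain carbon bound to a sulfur. Going by the values given here, this is the same kind of change as the one from compound 1 to compound 2, at the same place, only set on a core that carries bromo instead of chloro. Since that earlier change left compound 2 at the limit, as > 50 ug/mL shows, compound 4 is expected to stay at the limit as well, so the step that the limit leaves unreadable from compound 3 to compound 4 is an expectation that the assay will again report no number. The estimated value for compound 4 in this assay is 80 ug/mL, with a range from 40 ug/mL to 200 ug/mL.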

Compound 4, half-maximal inhibitory concentration: > 50 ug/mL
Compound 4 ended at the assay's limit (the forecaster's own chance of this, stated with the estimate: 85%); the middle value is on the limit's open side.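

Compound 4 gives > 50 ug/mL, which is a limit and not a number. No step can be read from compound 3 to compound 4 or from compound 2 to compound 4, as both pairs hold only limits. All four compounds stand at the same place: the limit of > 50 ug/mL in this assay, at which 4 of the 4 values shown sit.

These compounds leave open how strongly any of them inhibits, and whether phenyl in place of decyl or bromo in place of chloro changes that at all.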